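A Chloro Added to a Weakly Cytotoxic Series

This account rests on a few compounds, and the source may have more. Where it says the series, first, only, none or still open, it means among the compounds named here.

Compound 3 `Cc1ccc(-c2nnc(N3CCN(C(=O)CN4CCN(c5ccccc5)CC4)CC3)nc2-c2ccc(C)cc2)cc1` is the only one of the three measured compounds with an actual number in a functional assay on MCF7 cells (Homo sapiens) for cytotoxicity, read by MTT assay, with a stated time of 24 h (on this read-out lower numbers stand for stronger inhibition and higher numbers for weaker inhibition), where compound 3 gives 914000 nM. Compound 1 `COc1cccc(N2CCN(CC(=O)N3CCN(c4nnc(-c5ccccc5)c(-c5ccccc5)n4)CC3)CC2)c1` reaches only the limit of the assay in this assay, at > 910000 nM. Compound 2 `O=C(CN1CCN(c2ccc([N+](=O)[O-])cc2)CC1)N1CCN(c2nnc(-c3ccccc3)c(-c3ccccc3)n2)CC1` likewise gives only a limit in this assay, at > 886000 nM. Going by the values given here, the single measured step, a step that the two limits leave unreadable from compound 1 to compound 2, therefore says nothing about size. Compound 4 `Cc1ccc(-c2nnc(N3CCN(C(=O)CN4CCN(c5ccccc5Cl)CC4)CC3)nc2-c2ccc(C)cc2)cc1` differs from compound 3 by chloro in place of hydrogen on an aromatic carbon. Among the compounds with values here, no measured step concerns a chloro entering, so the step is expected to stay within the scatter, a 1.0-fold lower number from compound 3 to compound 4 (0.01 log units; within the scatter). Compound 4 is therefore expected to give 900000 nM in this assay, within 400000 nM to 2000000 nM, quite possibly again only as a limit.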

Compound 4, half-maximal inhibitory concentration: 859000 nM
For compound 4 the middle estimate is 1.0-fold (0.02 log units) above the measured one; low and high end bracket the measured number.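

In this assay, going by these compounds alone, the chloro provides the first readable step in these compounds, a 1.1-fold lower number from compound 3 to compound 4 (0.03 log units; within the scatter). The earlier pair offered only a step that its limits left unreadable, whereas this result shows that phenyl to 2-chlorophenyl, with the chloro ortho to a large group, leaves the number unchanged within the scatter. Nothing measured here offers a reason for this result. On these data alone, whether an amine or a carboxylic acid on this same aromatic ring would shift the number beyond the scatter remains open. So does the effect of a chloro on another carbon of that ring.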